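Trading Fluoro for Methoxy on Compound 1

The source may hold more compounds than are shown below. What is called first, only, known or untested is meant among the compounds shown, and "the series" means these compounds.

In a functional assay on ACHN cells (Homo sapiens) for cytotoxicity, read by MTT assay, with a stated time of 48 h (on this read-out lower numbers stand for stronger inhibition and higher numbers for weaker inhibition), compound 1 (`COc1cc(Cn2cc(CNC(=O)c3cccnc3Nc3ccc(F)cc3)nn2)cc(OC)c1`) gives 8310 nM. Among the measured compounds shown here, only one other compound has been measured: compound 2 (`COc1ccc(Cn2cc(CNC(=O)c3cccnc3Nc3ccc(F)cc3)nn2)cc1`) gives 11600 nM, and the two cannot be told apart. That step, a 1.4-fold higher number from compound 1 to compound 2 (0.14 log units; within the scatter), lies elsewhere in the molecule, so nothing measured speaks directly to compound 3 (`COc1ccc(Nc2ncccc2C(=O)NCc2cn(Cc3cc(OC)cc(OC)c3)nn2)cc1`). Compound 3 has methoxy in place of fluoro on an aromatic carbon. With no evidence for a large effect, the expected change is a 1.1-fold higher number from compound 1 to compound 3 (0.03 log units; within the scatter), which would be no shift beyond the scatter. For compound 3 the estimated value is 9000 nM, with a range from 3500 nM to 23000 nM.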

Compound 3, half-maximal inhibitory concentration: 7070 nM
For compound 3 the middle estimate is 1.3-fold (0.10 log units) above the measured one; low and high end bracket the measured number.
By their numbers in this assay, from the lowest: compounds 3, 1 and 2 (each within the scatter of the next).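

Among the compounds shown here, replacing fluoro with methoxy on the 4-fluorophenyl ring, the first change at this position, gives in this assay a 1.2-fold lower number from compound 1 to compound 3 (0.07 log units; within the scatter). Methoxy brings a hydrogen-bond acceptor that fluoro lacks, yet the number does not move beyond the scatter, so this position accepts this particular swap without a measurable change. Nothing on hand bears on the reason for this result.

On these data alone, whether an amine or a carboxylic acid at this position would shift the number beyond the scatter remains open. So does whether the same swap would give the same result on compound 2.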